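A few compounds are considered here, and "the series" means these few. Any claim that something is new, unique, unknown or untested is made for them only; others in the source may bear on it.

In a functional assay on NCI-H1299 cells (Homo sapiens) for antiproliferative activity, read by XTT assay, with a stated time of 72 h (a lower number here means a stronger inhibitor, a higher number a weaker inhibitor), compound 1, with the structure `COc1ccc(-c2cc3ccccc3nc2C=O)cc1`, gives only a limit, > 10000 nM, and so no number is known for it; this is the assay limit (the limit of > 10000 nM in this assay, at which 1 of the 3 values shown sits). Compound 2, `COc1ccc(-c2cc3ccccc3nc2/C=C/C(=O)c2c(OC)cccc2OC)cc1`, gives 4710 nM in this assay, and compound 3, `COc1ccc(-c2cc3ccccc3nc2/C=C/C(=O)c2ccccn2)cc1`, gives 660 nM. The one step measured between two numbers is a 7.1-fold lower number from compound 2 to compound 3 (0.85 log units; beyond the scatter), and on the numbers shown compound 3 stands lowest, with compound 2 as its nearest neighbour.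

Compound 4, `COc1ccc(-c2cc3ccccc3nc2/C=C/C(=O)c2ccsc2)cc1`, differs from compound 3 in one place: thiophen-3-yl in place of pyridin-2-yl on a carbonyl carbon. Going by the values given here, the only measured step at this carbonyl carbon, the step from compound 2 to compound 3, was of modest size and beyond the scatter, which shows that the group on this carbon matters in this assay. For compound 4 the change is expected to move the number back towards that of compound 2, so a step of a 2.3-fold higher number from compound 3 to compound 4 (0.36 log units; beyond the scatter) upward is expected. Compound 4 is therefore estimated at 1500 nM in this assay, with a range from 400 nM to 6000 nM.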

Compound 4, half-maximal inhibitory concentration: 1220 nM
Compound 4: middle estimate off by 1.2-fold (0.09 log units), on the high side; the range from low to high includes it.
By their numbers in this assay, from the lowest: compounds 3 and 4 (each within the scatter of the next); then compound 2. At a limit, above all of these: compound 1.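

In this assay, a five-membered aromatic ring with sulfur serves on this carbonyl carbon about as well as a six-membered one with nitrogen: a 1.8-fold higher number from compound 3 to compound 4 (0.27 log units; within the scatter). Thiophen-3-yl also holds most of the advantage over 2,6-dimethoxyphenyl, a 3.9-fold lower number from compound 2 to compound 4 (0.59 log units; beyond the scatter), so the earlier gain is not peculiar to pyridin-2-yl and its ring nitrogen. Replacing formyl with 2-((thiophen-3-yl)carbonyl)ethenyl gives an at least 8.1-fold lower number from compound 1 to compound 4 (0.91 log units; beyond the scatter), a step set against a limit and not against a number: the limit of > 10000 nM in this assay, at which 1 of the 4 values shown sits.

The compounds shown leave open whether a non-aromatic group such as piperidin-1-yl would hold the number on this carbonyl carbon, or whether an aromatic ring is needed at all. They also leave open how plain phenyl would compare, which would separate the part played by the two methoxy groups of compound 2 from that of the ring itself.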